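Moving a hydroxyl around a triaryl pyridine scaffold

A few compounds are considered here, and "the series" means these few. Any claim that something is new, unique, unknown or untested is made for them only; others in the source may bear on it.

Measured compounds:
compound 1 `Oc1ccc(-c2cc(-c3ccc(O)cc3)nc(-c3ccc(O)cc3)c2)cc1`: 790 nM
compound 2 `Oc1ccc(-c2cc(-c3ccccc3O)cc(-c3ccccc3O)n2)cc1`: 6990 nM
compound 3 `Oc1ccc(-c2cc(-c3cccc(O)c3)nc(-c3ccccc3O)c2)cc1`: 7420 nM

Three hydroxyphenyl-substituted analogues were tested in an ADME assay on HEK293 cells (Homo sapiens) for cytotoxicity, read by CCK-8 assay, with a stated time of 4 days; a higher number here means a weaker inhibitor, a lower number a stronger inhibitor. Compound 1, carrying three 4-hydroxyphenyl groups, gives 790 nM in this assay, the lowest number of the set. Compound 2 gives 6990 nM and compound 3 gives 7420 nM in this assay; these two values lie within the usual scatter of each other, so no order between them can be claimed. Compound 3 thus stands at the highest of the three numbers, with compound 2 close beside it and compound 1 well apart, beyond the scatter.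

Compound 4 `Oc1ccc(-c2cc(-c3cccc(O)c3)nc(-c3cccc(O)c3)c2)cc1` has not yet been measured. Relative to compound 3 the change is 3-hydroxyphenyl in place of 2-hydroxyphenyl on an aromatic carbon, on the carbon next to the ring nitrogen, so that compound 4 carries two 3-hydroxyphenyl groups and one 4-hydroxyphenyl group. Among the measured compounds shown here, no measured pair shows this exact change, so its effect is unknown here. A modest move toward a lower number is expected, expressed as a 1.9-fold lower number from compound 3 to compound 4 (0.27 log units; within the scatter), possibly no further than the scatter itself. For compound 4 the estimate in this assay is 4000 nM, with a range from 1200 nM to 13000 nM.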

Compound 4, half-maximal inhibitory concentration: 730 nM
Estimate against measurement, compound 4: 5.5-fold (0.74 log units) above, and the stated range ends above it.
By their numbers in this assay, from the lowest: compounds 4 and 1 (each within the scatter of the next); then compounds 2 and 3 (each within the scatter of the next).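

In this assay, putting 3-hydroxyphenyl in place of 2-hydroxyphenyl on the aromatic carbon next to the ring nitrogen gives a 10-fold lower number from compound 3 to compound 4 (1.01 log units; beyond the scatter), a step beyond the scatter. The earlier compounds shown here offered no pair differing in one place, whereas these two hold the same atoms, joined differently, and the leaving and entering groups match in every count, so this pair shows that relocating a single hydroxyl on this one phenyl ring can by itself go with a large change in the read-out. The compounds shown offer no measurement that accounts for the size or origin of this step.

The compounds shown leave open whether the same relocation of the hydroxyl would give a step of similar size on the other aryl groups of the shared core, and how 4-hydroxyphenyl on this same carbon would compare with the two groups exchanged here. They also leave open what would follow if the hydroxyl on this phenyl ring gave way to an amine, a methoxy group or a carboxylic acid.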